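Fluoro-to-hydrogen step on the benzylamide of compound 3

A few compounds are considered here, and "the series" means these few. Any claim that something is new, unique, unknown or untested is made for them only; others in the source may bear on it.

Measured so far, in an assay on cells for inhibition of Voltage-dependent T-type calcium channel subunit alpha-1H (Homo sapiens), read by patch clamp, tested at 10 uM; a lower number here means less inhibition, a higher number more inhibition at the concentration tested (going by the name of the read-out):
compound 1 `CN(C)CCCCCSC1=Nc2ccccc2C(CC(=O)NCc2ccccc2)N1c1ccc(-c2ccc(F)cc2)cc1` gives 75.6%
compound 2 `CN(C)CCCCCSC1=Nc2ccccc2C(CC(=O)NCc2ccccc2)N1c1ccc(-c2ccccc2)cc1` gives 83.9%
compound 3 `O=C(CC1c2ccccc2N=C(SCCCCCN2CCCC2)N1c1ccc(-c2ccc(F)cc2)cc1)NCc1ccc(F)cc1` gives 76.6%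

Compound 1 and compound 2 differ in one place only: hydrogen in place of fluoro on an aromatic carbon. This gives a number 8.3 percentage points higher from compound 1 to compound 2 (within the scatter), so the pair reads as two values that cannot be told apart. Compound 3 carries a different core; how it differs from compound 1 is not broken down here. Its value sits among those of compound 1 and compound 2 within the scatter.

Compound 4 `O=C(CC1c2ccccc2N=C(SCCCCCN2CCCC2)N1c1ccc(-c2ccc(F)cc2)cc1)NCc1ccccc1` has not yet been measured in this assay. It is made from compound 3 by hydrogen in place of fluoro on an aromatic carbon. This is the same change as that from compound 1 to compound 2, at the same kind of place, but on a different core. Because the earlier step was a number 8.3 percentage points higher from compound 1 to compound 2 (within the scatter), the step from compound 3 to compound 4 is expected to stay small as well, estimated at a number 3.4 percentage points higher from compound 3 to compound 4 (within the scatter). The estimate for compound 4 is therefore 80%, expected to fall between 68% and 90%.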

Compound 4, a percentage reported as inhibition, at one concentration (the size of the read-out at that concentration, not a potency): 97.5%
Compound 4: the middle estimate sits 17.5 percentage points below what was measured, outside the stated range (above it).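

In this assay, hydrogen in place of fluoro, here 4-fluorobenzyl to benzyl, gives a number 20.9 percentage points higher from compound 3 to compound 4 (beyond the scatter). The same change on the two cores points the same way, and the two steps cannot be told apart: the same change on two cores in this assay, a number 8.3 percentage points higher (within the scatter) from compound 1 to compound 2 and a number 20.9 percentage points higher (beyond the scatter) from compound 3 to compound 4, 12.6 percentage points apart, within the scatter of two such steps. Within the data shown here, this is a shared direction across only two pairs, one of them within the scatter on its own, so it does not show that the size of the step carries over from one core to another, or that the direction would hold on a further core.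

Pyrrolidin-1-yl in place of dimethylamino gives a number 21.9 percentage points higher from compound 1 to compound 4 (beyond the scatter), but this rests on a single pair, and it remains open whether the step holds for other amines at the chain end, such as piperidine or morpholine. Also open, on these data alone, is how a chloro or methoxy group would compare with fluoro and hydrogen on the same aromatic carbon, and how a shorter chain to the amine would read.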